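This account rests on a few compounds, and the source may have more. Where it says the series, first, only, none or still open, it means among the compounds named here.

Measured compounds:
Compound 1, `Nc1scc(CN2CCN(c3cccc(Cl)c3Cl)CC2)c1C(=O)c1ccc(Cl)cc1`: 0%
Compound 2, `Nc1scc(CN2CCN(C3CCCCCC3)CC2)c1C(=O)c1ccc(Cl)cc1`: 0%
Compound 3, `Nc1scc(CN2CCN(c3cc(F)ccc3F)CC2)c1C(=O)c1ccc(Cl)cc1`: 2%

In an assay on CHO cells for displacement of a labelled ligand from adenosine receptor A3 (Homo sapiens), read by scintillation counting, with a stated time of 120 min, tested at 10 uM (on this read-out higher numbers stand for more inhibition at the one concentration tested (going by the name of the read-out) and lower numbers for less inhibition), compound 1 gives 0%. Compound 2 gives the same reading, and the step of no change at the digits printed from compound 1 to compound 2 (within the scatter) is within the scatter. Compound 3 is the furthest of the three from compound 1, yet the step of a number 2 percentage points higher from compound 1 to compound 3 (within the scatter) also stays within the scatter, as does the step of a number 2 percentage points higher from compound 2 to compound 3 (within the scatter). All three readings therefore describe the same picture: the shared core carries essentially no inhibition at the concentration tested, whatever sits on the amine nitrogen in a ring.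

Compound 4, `Nc1scc(CN2CCN(c3ccc(F)c(Cl)c3)CC2)c1C(=O)c1ccc(Cl)cc1`, differs from compound 1 in that one place: 3-chloro-4-fluorophenyl in place of 2,3-dichlorophenyl on an amine nitrogen in a ring. Every measured step bears on this change, since each of them swaps the group on the same amine nitrogen in a ring, and none of them moved the reading beyond the scatter. A single aromatic ring with two halogens in a different arrangement gives no ground to expect anything different, so the step of a number 1 percentage points higher from compound 1 to compound 4 (within the scatter) is expected to fall within the scatter as well. In this assay compound 4 is therefore estimated at 1%, with a range from -8% to 12%.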

Compound 4, a percentage reported as inhibition, at one concentration (the size of the read-out at that concentration, not a potency): 0%
Compound 4: middle estimate off by 1 percentage points, on the high side, within the range that was stated.
By their numbers in this assay, from the lowest: compounds 1, 2, 4 and 3 (each within the scatter of the next).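

In this assay, the step of no change at the digits printed from compound 1 to compound 4 (within the scatter) shows that a phenyl group carrying both chlorine and fluorine, as 3-chloro-4-fluorophenyl, reads the same on this amine nitrogen in a ring as 2,3-dichlorophenyl, a group with chlorine alone. The reading also cannot be told apart from those of the other two groups, with the step of a number 2 percentage points lower from compound 3 to compound 4 (within the scatter) against 2,5-difluorophenyl and the step of no change at the digits printed from compound 2 to compound 4 (within the scatter) against cycloheptyl, so all four listed groups now sit within the scatter of one another on the shared core. Nothing measured alongside these readings helps to explain this flat result.

The compounds shown leave open whether a group of a different kind on this nitrogen, such as a phenyl ring bearing a carboxylic acid, a pyridine ring or a short chain ending in an amine, would give a reading that departs from this level. They also leave open whether replacing the 4-chlorophenyl on the carbonyl, or the free amine of the shared core, with another group would change this assay at all.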